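The source may hold more compounds than are shown below. What is called first, only, known or untested is meant among the compounds shown, and "the series" means these compounds.

Measured so far in a functional assay on Capan-2 cells (Homo sapiens) for inhibition, read by MTT assay, with a stated time of 72 h; on this read-out higher numbers stand for lower toxicity in this test and lower numbers for higher toxicity in this test:

- compound 1 `CC(C)(Oc1ccc(CCOc2ccc(NC(=O)c3ccccc3)cc2)cc1)C(=O)NS(=O)(=O)c1ccccc1`: 7000 nM
- compound 2 `CC(C)(Oc1ccc(CCOc2ccc(/N=N/c3ccccc3)cc2)cc1)C(=O)NS(=O)(=O)c1ccc(Cl)cc1`: > 24000 nM

Compound 1 gives a true number, 7000 nM. Compound 2 stands at the limit of > 24000 nM in this assay, at which 1 of the 2 values shown sits. Its reading of > 24000 nM is a limit of the test and not a number.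

The next compound to be tested is compound 3 `CC(C)(Oc1ccc(CCOc2ccc(/N=N/c3ccccc3)cc2)cc1)C(=O)NS(=O)(=O)c1ccc([N+](=O)[O-])cc1`. It keeps all of compound 2 except one group, with nitro in place of chloro on an aromatic carbon, para to a large group: nitro in place of chloro on an aromatic carbon.

For the measured compounds named here, no pair of measured compounds shows what such a swap does. The expectation in this assay is therefore no step beyond the usual scatter, in neither direction. The expected change a number no higher from compound 2 to compound 3 (the limit leaves the size open) is small, and the test may again report only a limit. For compound 3 the estimated value is 24000 nM, with an expected range of 10000 nM to 50000 nM.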

Compound 3, half-maximal cytotoxic concentration: > 24000 nM
Compound 3: no number, only a limit; the forecaster's own chance of this, stated with the estimate: 60%; the middle value sits exactly at the limit.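

Compound 2 and compound 3 each give only a limit and not a number, so no step can be read between them: the limit of > 24000 nM in this assay, at which 2 of the 3 values shown sit. As far as these compounds go, whether nitro in place of chloro on an aromatic carbon changes the half-maximal cytotoxic concentration at all stays open.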